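A few compounds are considered here, and "the series" means these few. Any claim that something is new, unique, unknown or untested is made for them only; others in the source may bear on it.

Values in an ADME assay on MDBK cells (Bos taurus) for cytotoxicity (on this read-out lower numbers stand for higher toxicity in this test and higher numbers for lower toxicity in this test), so far:
Compound 1 `Fc1cccc(F)c1Cn1ccc2nc(-c3c(F)cccc3F)nc-2c1` gives > 100000 nM as a limit of the assay
Compound 2 `Fc1cccc(F)c1Cn1c(-c2c(F)cccc2F)nc2ccncc21` gives 99000 nM as a number
Compound 3 `COc1ccccc1Cn1ccc2nc(-c3ccccc3)nc-2c1` gives > 100000 nM as a limit of the assay

Compound 3 has no number, only a limit of the assay (the limit of > 100000 nM in this assay, at which 2 of the 3 values shown sit). Compound 4 `Clc1ccc(Cn2ccc3nc(-c4ccccc4)nc-3c2)cc1` has 4-chlorophenyl in place of 2-methoxyphenyl on a saturated chain carbon bound to an aromatic nitrogen. Within the data shown here, no measured single-place step sizes this change. Compound 2 shows that a number can be read in this range (99000 nM). In this assay a modest step toward lower numbers is expected (an at least 1.4-fold lower number from compound 3 to compound 4 (0.15 log units; that floor lies within the scatter)), possibly none beyond the scatter. For compound 4 the estimate is 70000 nM with an estimated range of 25000 nM to 100000 nM around it.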

Compound 4, half-maximal cytotoxic concentration: > 100000 nM
Compound 4 ended at the assay's limit (the forecaster's own chance of this, stated with the estimate: 45%); middle value at least 1.4-fold (0.15 log units) away from the limit.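

In this assay, among these compounds, compound 3 and compound 4 both sit at a limit of the assay, so no step between them can be read. The compounds shown leave open whether 4-chlorophenyl in place of 2-methoxyphenyl changes this read-out at all.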